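The source may hold more compounds than are shown below. What is called first, only, known or untested is meant among the compounds shown, and "the series" means these compounds.

Measured compounds:
compound 1, `Cc1nn(-c2ncnc3nc[nH]c23)c2c1C(OCC(=O)c1ccc(F)cc1)CC(=O)N2`: 973 nM
compound 2, `Cc1nn(-c2ncnc3nc[nH]c23)c2c1C(OCc1cc(F)cc3c1OCOC3)CC(=O)N2`: 30 nM
compound 3, `Cc1nn(-c2ncnc3nc[nH]c23)c2c1C(c1ccc(OC(C)C)cc1)CC(=O)N2`: 2700 nM

In a functional assay on HEK293 cells for agonist activity at G-protein coupled receptor 39 (Homo sapiens), read by scintillation proximity assay and inositol phosphate accumulation, with a stated time of 75 min (a lower number here means that less compound is needed, a higher number that more compound is needed for the effect), compound 3 gives the highest number of the three, so it needs the most compound for the effect; compound 1 is closer to it, and compound 2 is far lower, both differences beyond the scatter. The unmeasured compound 4, `Cc1nn(-c2ncnc3nc[nH]c23)c2c1C(OCCc1ccccc1)CC(=O)N2`, changes compound 3 by phenethyloxy in place of 4-isopropoxyphenyl on a saturated ring carbon. Compound 4 thus carries its aromatic ring through an oxygen on a saturated carbon, as compounds 1 and 2 do, rather than directly on the ring carbon as in compound 3. Going by the values given here, the only measured step, a 32-fold lower number from compound 1 to compound 2 (1.51 log units; beyond the scatter), concerns the group beyond that oxygen and shows how widely the numbers within that oxygen-linked arrangement can swing, but no step separates a directly bound aryl from an oxygen-linked one. The values show that both oxygen-linked compounds give lower numbers than compound 3 in this assay. For compound 4 a lower number than compound 3 is therefore expected, a step of about a 4.5-fold lower number from compound 3 to compound 4 (0.65 log units; beyond the scatter), with wide uncertainty. Compound 4 is estimated at 600 nM, between 120 nM and 3000 nM.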

Compound 4, half-maximal effective concentration: 40 nM
Beside the measured number, compound 4's estimate is 15-fold (1.18 log units) above it, and the stated range ends above it.
By their numbers in this assay, from the lowest: compounds 2 and 4 (each within the scatter of the next); then compound 1; then compound 3.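

In this assay, going by these compounds alone, the change at this saturated ring carbon gives a 68-fold lower number from compound 3 to compound 4 (1.83 log units; beyond the scatter), the first step to compare an aromatic ring bound directly to that carbon with one reached through an oxygen and a chain; phenethyloxy and 4-isopropoxyphenyl have the same aromatic ring and the same donor and acceptor counts, yet the numbers lie far apart. Among the oxygen-linked compounds, benzyl in place of (4-fluorophenyl)carbonyl on the chain carbon gives a 24-fold lower number from compound 1 to compound 4 (1.39 log units; beyond the scatter), so the group beyond the oxygen also matters greatly. The plain benzyl also gives a 1.3-fold higher number from compound 2 to compound 4 (0.12 log units; within the scatter), showing that among these compounds, the second ring with two oxygens and the fluorine of compound 2 is not required to reach a low number.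

No measurement shown here gives a reason for these differences. Going by these compounds, since the step to compound 4 changes the linking oxygen, the chain and the removal of isopropoxy together, the contribution of each stays open, as does whether an amine in place of the oxygen or a longer chain such as 3-phenylpropoxy would keep the number low.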